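A few compounds are considered here, and "the series" means these few. Any claim that something is new, unique, unknown or untested is made for them only; others in the source may bear on it.

Compound 3 `FC(F)(F)c1cccc(N2CCN(CCCN3CC4CCCCN4C3)CC2)c1` gives 278 nM in an assay on membranes from Cerebral cortex with Alpha-1A adrenergic receptor (Rattus norvegicus) as the target, read by radioligand binding; on this read-out higher numbers stand for weaker inhibition and lower numbers for stronger inhibition. Among the three compounds with numbers, compound 3 holds the highest number: compound 2 `COc1ccccc1N1CCN(CCCN2CC3CCCCN3C2)CC1` gives 218 nM in this assay, a value that sits within the scatter of compound 3, so nothing separates the two. Compound 1 `O=C1C2CCCN2C(=O)N1CCCCN1CCN(c2cccc(C(F)(F)F)c2)CC1` gives 64.9 nM in this assay, a lower number that stands beyond the scatter from compound 3.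

Compound 4 `FC(F)(F)c1cccc(N2CCN(CCCCN3CC4CCCN4C3)CC2)c1` has the same atoms as compound 3, joined differently: a group of 9 heavy atoms (7 carbon, 2 nitrogen; one five-membered non-aromatic ring with 1 hetero atom, one five-membered non-aromatic ring with 2 hetero atoms) in place of a group of 9 heavy atoms (7 carbon, 2 nitrogen; one five-membered non-aromatic ring with 2 hetero atoms, one six-membered non-aromatic ring with 1 hetero atom), on a saturated chain carbon, three bonds along the chain from an amine nitrogen in a ring. Within the data shown here, no pair of measured compounds shows a step of this kind, so the data give no direct measure of its size. Compound 1 carries a longer chain together with a different ring system, so it cannot be read as a guide to the chain length alone.

For compound 4 the expected step of a 1.1-fold lower number from compound 3 to compound 4 (0.05 log units; within the scatter) is therefore taken as none beyond the scatter, in either direction. The estimated value for compound 4 in this assay is 250 nM, with a range from 80 nM to 800 nM.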

Compound 4, inhibition constant: 240 nM
Estimate against measurement, compound 4: 1.0-fold (0.02 log units) above; low and high end bracket the measured number.
By their numbers in this assay, from the lowest: compound 1; then compounds 2, 4 and 3 (each within the scatter of the next).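

At this chain position, the two ways of joining the same atoms are not told apart in this assay: a 1.2-fold lower number from compound 3 to compound 4 (0.06 log units; within the scatter), so the five-membered and six-membered ring pairings, each with its own chain, read alike here. Compound 4 also links compound 1 to the rest of the set through a single place, on a saturated chain carbon, four bonds along the chain from an amine nitrogen in a ring, where a group without oxygen replaces a group with oxygen and gives a 3.7-fold higher number from compound 1 to compound 4 (0.57 log units; beyond the scatter). No measurement at hand explains either step.

The compounds shown leave open whether a group with a single carbonyl would read like compound 1 or like compound 4. They also leave open how a pentyl chain would read, and whether the step between compound 1 and compound 4 would recur with a 2-methoxyphenyl group on the piperazine.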